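From 3-Fluorophenoxy to 3,4-Difluorophenoxy: Expecting Compound 4

The compounds below may be only part of what the source reports. "The series", "measured", "known", "first", "only" and "open" are said of these compounds alone.

Measured compounds and their values in a functional assay on SMMC-7721 cells (Homo sapiens) for antiproliferative activity, read by MTT assay, with a stated time of 72 h; on this read-out lower numbers stand for stronger inhibition and higher numbers for weaker inhibition:
- Compound 1, `Cc1nn(C)c(Oc2ccc(Cl)cc2)c1/C=N\CCCCCOc1cc2oc(=O)cc(C)c2cc1Cl`, gives 17500 nM.
- Compound 2, `Cc1nn(C)c(Oc2ccc(I)cc2)c1/C=N\CCCCCOc1cc2oc(=O)cc(C)c2cc1Cl`, gives only a limit, > 25000 nM.
- Compound 3, `Cc1nn(C)c(Oc2cccc(F)c2)c1/C=N\CCCCCCOc1cc2oc(=O)cc(C)c2cc1Cl`, gives 23600 nM.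

Compound 3 stands alongside compound 1: the gap between the two numbers is within the scatter, so neither can be called the stronger. Compound 2 sits at the limit of this assay (the limit of > 25000 nM in this assay, at which 1 of the 3 values shown sits), and so gives no number to compare.

Compound 4, `Cc1nn(C)c(Oc2ccc(F)c(F)c2)c1/C=N\CCCCCCOc1cc2oc(=O)cc(C)c2cc1Cl`, differs from compound 3 in one place: fluoro in place of hydrogen on an aromatic carbon.

Only one measured step exists among these compounds, and it concerns a different change. In this assay the step of an at least 1.4-fold higher number from compound 1 to compound 2 (0.15 log units; that floor lies within the scatter) swaps one halogen for another on the same ring and reaches only the limit, a floor that is itself within the scatter. Among the compounds with values here, it says little about a fluoro group entering beside an existing fluoro group, and no measured pair shows a fluoro group replacing hydrogen. With no step beyond the scatter anywhere in the set, compound 4 is expected to stay close to compound 3, with the step of a 1.0-fold higher number from compound 3 to compound 4 (0.01 log units; within the scatter) not expected to exceed the scatter.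

The estimate for compound 4 in this assay is 24000 nM, within a range from 12000 nM to 48000 nM.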

Compound 4, half-maximal inhibitory concentration: > 25000 nM
Compound 4: a limit, no number (the forecaster's own chance of this, stated with the estimate: 40%); at least 1.0-fold (0.01 log units) between middle value and limit.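

Fluoro in place of hydrogen on an aromatic carbon, ortho to a fluoro group and para to a large group, can now be read for the first time in this assay, as an at least 1.0-fold higher number from compound 3 to compound 4 (0.02 log units; that floor lies within the scatter). From the compounds shown here alone, this step is only a floor, so its true size stays unknown, but the added fluoro group on the 3-fluorophenoxy ring of compound 4 gives no sign of stronger inhibition at this position. Compound 4 gives a limit and no number, and, with compound 2, it brings the limits in this small set level with the measured numbers: the limit of > 25000 nM in this assay, at which 2 of the 4 values shown sit.

The compounds shown leave open what an amine or a carboxylic acid in place of the new fluoro group would give in this assay, and whether any group at this position can give a clear step toward stronger inhibition. Within the data shown here, they also leave open how the 3,4-difluorophenoxy group would read on a longer chain, since no pair here isolates a change of chain.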